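Moving the chlorine on the benzyl ring of compound 2

The compounds below may be only part of what the source reports. "The series", "measured", "known", "first", "only" and "open" are said of these compounds alone.

Measured so far:
compound 1, `CC(C)(C)c1ccc(CNCCNS(=O)(=O)c2cc(C(F)(F)F)cc(C(F)(F)F)c2)cc1`: 13000 nM
compound 2, `O=S(=O)(NCCCNCc1ccc(Cl)cc1)c1cc(C(F)(F)F)cc(C(F)(F)F)c1`: 4900 nM
compound 3, `CC(C)(C)c1ccc(CNCCCNS(=O)(=O)c2cc(C(F)(F)F)cc(C(F)(F)F)c2)cc1`: 2500 nM

All three were tested in a functional assay on PANC-1 cells (Homo sapiens) for inhibition, read by MTT assay, with a stated time of 72 h (a lower number here means a stronger inhibitor of growth, a higher number a weaker inhibitor of growth), and share one core. Compound 2 stands second highest of the three numbers; its nearest neighbour is compound 3, reached by a 2.0-fold lower number from compound 2 to compound 3 (0.29 log units; within the scatter), while compound 1 gives a higher number that lies beyond the scatter. Compound 4, `O=S(=O)(NCCCNCc1cccc(Cl)c1)c1cc(C(F)(F)F)cc(C(F)(F)F)c1`, has not been measured. It differs from compound 2 by 3-chlorophenyl in place of 4-chlorophenyl on a saturated chain carbon bound to an amine nitrogen. Going by the values given here, no measured step moves a chlorine around that ring; the only measured change at that place, replacing chloro with tert-butyl, stayed within the scatter. Therefore no step beyond the scatter is expected in this assay, and the expected step is a 1.0-fold higher number from compound 2 to compound 4 (0.01 log units; within the scatter). Compound 4 is estimated at 5000 nM, with a range from 2000 nM to 12000 nM.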

Compound 4, concentration for 50% growth inhibition: 12000 nM
The estimate for compound 4 lay 2.4-fold (0.38 log units) below the measured number, within the range that was stated.
By their numbers in this assay, from the lowest: compounds 3 and 2 (each within the scatter of the next); then compounds 4 and 1 (each within the scatter of the next).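

In this assay, shifting the chlorine from 4-chlorophenyl to 3-chlorophenyl gives a 2.4-fold higher number from compound 2 to compound 4 (0.39 log units; beyond the scatter), so the place of the chlorine on this ring matters, even though replacing chloro with tert-butyl earlier stayed within the scatter. Replacing the 4-(tert-butyl)phenyl group with 3-chlorophenyl gives a 4.8-fold higher number from compound 3 to compound 4 (0.68 log units; beyond the scatter), a step in the same direction. No evidence here explains why the chlorine's place changes the number. Still open, from the compounds shown here alone, is whether a fluorine or a methoxy group in place of that chlorine would give a similar number in this assay or a different one.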